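This account rests on a few compounds, and the source may have more. Where it says the series, first, only, none or still open, it means among the compounds named here.

Compound 1 `Cc1cc(C#N)cc(C)c1Oc1ccnc(S(=O)(=O)CC(=O)Nc2cccc(F)c2)n1`: 25900 nM
Compound 2 `Cc1cc(C#N)cc(C)c1Oc1ccnc(S(=O)(=O)CC(=O)Nc2ccc(Cl)cc2Cl)n1`: 10400 nM

In an ADME assay on MT4 cells (Homo sapiens) for cytotoxicity, read by MTT assay, with a stated time of 4 days (on this read-out higher numbers stand for lower toxicity in this test and lower numbers for higher toxicity in this test), compound 2 gives the lower of the two numbers, the measured step being a 2.5-fold lower number from compound 1 to compound 2 (0.40 log units; beyond the scatter). Compound 3 `Cc1cc(C#N)cc(C)c1Oc1ccnc(S(=O)(=O)CC(=O)Nc2cccc([N+](=O)[O-])c2)n1` differs from compound 2 by 3-nitrophenyl in place of 2,4-dichlorophenyl on an amide-type nitrogen. Among the compounds with values here, the only measured step at the same nitrogen, a 2.5-fold lower number from compound 1 to compound 2 (0.40 log units; beyond the scatter), is modest and runs downward, and compound 3 gives up the two chlorines that entered in that step, so a move back upward of comparable size is expected. Compound 3 is therefore estimated at 20000 nM, with a range from 8000 nM to 50000 nM. The expected step is a 1.9-fold higher number from compound 2 to compound 3 (0.28 log units; within the scatter).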

Compound 3, half-maximal cytotoxic concentration: 23600 nM
The estimate for compound 3 lay 1.2-fold (0.07 log units) below the measured number; the measured number falls inside the stated range.
By their numbers in this assay, from the lowest: compound 2; then compounds 3 and 1 (each within the scatter of the next).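

In this assay the 3-nitrophenyl group reverses the drop seen with 2,4-dichlorophenyl, with a 2.3-fold higher number from compound 2 to compound 3 (0.36 log units; beyond the scatter), while nitro in place of fluoro on an aromatic carbon stays within the scatter, with a 1.1-fold lower number from compound 1 to compound 3 (0.04 log units; within the scatter). Of the three groups on this amide-type nitrogen, only 2,4-dichlorophenyl stands apart, and 3-fluorophenyl and 3-nitrophenyl cannot be told apart. Nothing available here accounts for this difference. As far as these compounds go, it remains open whether a single chlorine is enough to give the lower number, and whether an amine or a carboxylic acid on the aromatic ring would match fluoro and nitro.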